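A few compounds are considered here, and "the series" means these few. Any claim that something is new, unique, unknown or untested is made for them only; others in the source may bear on it.

Measured compounds:
compound 1 `Cc1ccc(-c2nn(C(C)C)cc2C(=O)Nc2ccc(C)c(S(=O)(=O)N3CCOCC3)c2)cc1`: 1690 nM
compound 2 `COc1cccc(Cn2cc(C(=O)Nc3ccc(C)c(S(=O)(=O)N4CCOCC4)c3)c(C(C)C)n2)c1`: 3110 nM
compound 3 `COc1cccc(-c2nn(C(C)C)cc2C(=O)Nc2ccc(C)c(S(=O)(=O)N3CCOCC3)c2)c1`: 3490 nM

These three compounds share a core and were tested in an assay on HEK-293T cells for inhibition of Bile acid receptor (Homo sapiens), read by a beta-lactamase reporter, with a stated time of 16 h; on this read-out higher numbers stand for weaker inhibition and lower numbers for stronger inhibition. Compound 3 gives the highest of the three numbers in this assay, with 3490 nM. Its nearest neighbour is compound 2, whose value of 3110 nM lies within the scatter of compound 3, so no order between the two can be claimed. Compound 1, at 1690 nM, stands furthest away: the only single-point step among these compounds, a 2.1-fold higher number from compound 1 to compound 3 (0.31 log units; beyond the scatter), is a modest rise that is beyond the scatter.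

Compound 4 `COc1cccc(Cn2cc(C(=O)Nc3ccc(C)c(S(=O)(=O)N4CCOCC4)c3)c(-c3cccc(OC)c3)n2)c1` is not yet measured. It differs from compound 3 in one place: 3-methoxybenzyl in place of isopropyl on an aromatic nitrogen. Going by the values given here, no measured step changes the group on this ring nitrogen while holding everything else fixed, so there is no direct precedent. Compound 2 carries the same 3-methoxybenzyl group on that nitrogen, but it also differs from compound 3 at the other position, so its value only shows that such a compound can sit in the same range. The step from compound 3 to compound 4 is therefore expected to be small, a 1.0-fold higher number from compound 3 to compound 4 (0.00 log units; within the scatter), with no confident direction. Compound 4 is estimated at 3500 nM in this assay, within a range from 1400 nM to 9000 nM.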

Compound 4, half-maximal inhibitory concentration: 1240 nM
For compound 4 the middle estimate is 2.8-fold (0.45 log units) above the measured one, outside the stated range (below it).
By their numbers in this assay, from the lowest: compounds 4, 1, 2 and 3 (each within the scatter of the next, the first and the last beyond it).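

In this assay, replacing isopropyl with 3-methoxybenzyl on the aromatic nitrogen gives a 2.8-fold lower number from compound 3 to compound 4 (0.45 log units; beyond the scatter), so at this position a lower number goes with the larger group of 9 heavy atoms and its extra aromatic ring. The second route to the same compound, 3-methoxyphenyl in place of isopropyl on an aromatic carbon, gives a 2.5-fold lower number from compound 2 to compound 4 (0.40 log units; beyond the scatter), so the isopropyl group can be exchanged at either position without the number rising. Both steps end at compound 4, the only compound shown with an aromatic group at both positions, so this reading rests on a single compound.

The compounds shown do not separate the contribution of the benzyl ring from that of its methoxy group, and an unsubstituted benzyl group, a longer chain such as n-butyl, or a chain ending in an amine on the same nitrogen would test how far the trend extends. Nothing measured here explains why the number falls with either change.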